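Quinoline sulfone series: aryl and halogen swaps

The source may hold more compounds than are shown below. What is called first, only, known or untested is meant among the compounds shown, and "the series" means these compounds.

Measured so far:
compound 1 `CC1CCN(c2c(S(=O)(=O)c3cc(F)cc(F)c3)cnc3cc(Cl)ccc23)CC1`: 94%
compound 2 `Cc1ccc(S(=O)(=O)c2cnc3cc(Cl)ccc3c2N2CCC(C)CC2)cc1`: 94%
compound 3 `Cc1ccc(S(=O)(=O)c2cnc3cc(F)ccc3c2N2CCC(C)CC2)cc1`: 88%

All three numbers come from an assay on isolated protein for displacement of a labelled ligand from metabotropic glutamate receptor 5 (Homo sapiens), with a stated time of 60 min, tested at 1 uM; a lower number here means less inhibition, a higher number more inhibition at the concentration tested (going by the name of the read-out). Compound 2 and compound 1 share a core and differ only by 3,5-difluorophenyl in place of 4-methylphenyl on a sulfonyl sulfur; that change gave no change at the digits printed from compound 2 to compound 1 (within the scatter). Compound 2 and compound 3 differ in the core itself, by fluoro in place of chloro on an aromatic carbon, and that step was a number 6 percentage points lower from compound 2 to compound 3 (within the scatter). The three values thus sit together within the scatter, and no order among them can be read.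

Compound 4 `CC1CCN(c2c(S(=O)(=O)c3cc(F)cc(F)c3)cnc3cc(F)ccc23)CC1` is not yet measured. It carries the core of compound 3 and differs from it by 3,5-difluorophenyl in place of 4-methylphenyl on a sulfonyl sulfur. The place of this change is the same, word for word, as for the step from compound 2 to compound 1, so it is the same change made on the other core. Expected: no change at the digits printed from compound 3 to compound 4 (within the scatter), because no change at the digits printed from compound 2 to compound 1 (within the scatter) was the outcome of that change on the chloro core, with the fluoro core adding no separate information beyond compound 3. Compound 4 is estimated at 88% in this assay, with a range from 78% to 96% expected.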

Compound 4, a percentage reported as inhibition, at one concentration (the size of the read-out at that concentration, not a potency): 77%
Beside the measured number, compound 4's estimate is 11 percentage points above it; measured number below the stated range.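

In this assay, 3,5-difluorophenyl in place of 4-methylphenyl on a sulfonyl sulfur gave a number 11 percentage points lower from compound 3 to compound 4 (beyond the scatter), and the two steps for this change compare as follows: the same change on two cores in this assay, no change at the digits printed (within the scatter) from compound 2 to compound 1 and a number 11 percentage points lower (beyond the scatter) from compound 3 to compound 4, 11 percentage points apart, within the scatter of two such steps. Fluoro in place of chloro on an aromatic carbon, with 3,5-difluorophenyl on the sulfonyl sulfur, gave a number 17 percentage points lower from compound 1 to compound 4 (beyond the scatter), and the two steps for this change compare as follows: the same change on two cores in this assay, a number 6 percentage points lower (within the scatter) from compound 2 to compound 3 and a number 17 percentage points lower (beyond the scatter) from compound 1 to compound 4, 11 percentage points apart, within the scatter of two such steps. Among the compounds shown here, each change therefore carries from one core to the other within the scatter of two such steps, so these compounds do not show that either change depends on the core, nor, with only one pair of steps per change, do they prove that the two changes are independent.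

The compounds shown leave open how a sulfonyl aryl group carrying a nitrile or a carboxylic acid would behave on either core. Also open, as far as these compounds go, is whether the halogen swap would give a similar result with a longer chain in place of the methyl group on the amine ring.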